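The source may hold more compounds than are shown below. What is called first, only, known or untested is meant among the compounds shown, and "the series" means these compounds.

In a functional assay on A549 cells (Homo sapiens) for inhibition, read by MTT assay, with a stated time of 72 h (a lower number here means a stronger inhibitor, a higher number a weaker inhibitor), compound 3 `CC1=NN(c2ccccc2)C(=O)[C@]12C(=O)C=CC[C@H]2c1ccccc1` gives 8290 nM. Compound 3 lies within the scatter of compound 1 `CC1=NN(c2ccccc2)C(=O)[C@@]12C(=O)C=CC[C@H]2c1ccc(C)cc1` at 6090 nM, while the lower number of compound 2 `CC1=NN(c2ccccc2)C(=O)[C@@]12C(=O)C=CC[C@H]2c1cccc(C)c1`, 3500 nM, lies beyond the scatter from it. Compound 4 `CC1=NN(c2ccccc2)C(=O)[C@@]12C(=O)C=CC[C@H]2c1ccccc1` is related to compound 3 by one change: the two compounds have the same atoms and bonds and differ only in configuration as drawn: 1 of 2 stereo elements differ; a stereocentre at a saturated ring carbon is drawn S in compound 3 and R in compound 4. For the measured compounds named here, no measured step tests such a change directly. Going by the values given here, the only step available, a 1.7-fold lower number from compound 1 to compound 2 (0.24 log units; within the scatter), moves a methyl group and stays small. Compound 4 does share its drawn configuration with compound 1 and compound 2, so a modest drop is expected, a 1.7-fold lower number from compound 3 to compound 4 (0.22 log units; within the scatter), probably within the scatter. For compound 4 the estimated value is 5000 nM, with an expected range of 2300 nM to 11000 nM.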

Compound 4, half-maximal inhibitory concentration: 3770 nM
Estimate against measurement, compound 4: 1.3-fold (0.12 log units) above; measured number inside the range.
By their numbers in this assay, from the lowest: compounds 2, 4, 1 and 3 (each within the scatter of the next, the first and the last beyond it).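

In this assay, for the compounds shown here, the first step to test the configuration at this saturated ring carbon, a 2.2-fold lower number from compound 3 to compound 4 (0.34 log units; beyond the scatter), lies beyond the scatter, and it can be traced to that stereocentre alone: the fact that compounds 3 and 4 differ only in the configuration as drawn. Hydrogen in place of methyl on an aromatic carbon, by contrast, stays within the scatter, in both a 1.1-fold higher number from compound 2 to compound 4 (0.03 log units; within the scatter) and a 1.6-fold lower number from compound 1 to compound 4 (0.21 log units; within the scatter). From the compounds shown here alone, whether the same change of configuration gives a similar step with a 3-methylphenyl or 4-methylphenyl group remains open, as does whether an amine or a carboxylic acid on that aromatic ring would move the number beyond the scatter.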